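Swapping an Open-Chain Amine for a Ring on a Quinone Core

The compounds below may be only part of what the source reports. "The series", "measured", "known", "first", "only" and "open" are said of these compounds alone.

Compound 1 `COCCCNC1=CC(=O)c2nc(-c3ccccc3)ccc2C1=O` was tested in a functional assay on NCI60 cells (Homo sapiens) for cytotoxicity (on this read-out higher numbers stand for weaker inhibition of growth and lower numbers for stronger inhibition of growth), where compound 1 gives 3550 nM, the highest of the two numbers in hand. Among the measured compounds shown here, the only other measured compound is compound 2 `COc1cc(-c2ccc3c(n2)C(=O)C=C(N2CC2)C3=O)cc(OC)c1OC`, which in this assay gives 589 nM; it differs from compound 1 in more than one place, so its value offers no clean guide. Compound 3 `O=C1C(N2CCCC2)=CC(=O)c2nc(-c3ccccc3)ccc21` carries pyrrolidin-1-yl in place of (3-methoxypropyl)amino on a double-bonded ring carbon. For the measured compounds named here, with no measured step of this kind to lean on, the change from compound 1 to compound 3 is expected to stay within the scatter, a 1.2-fold lower number from compound 1 to compound 3 (0.07 log units; within the scatter). Compound 3 is therefore estimated at 3000 nM, between 1000 nM and 9000 nM.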

Compound 3, concentration for 50% growth inhibition: 44700 nM
Compound 3: middle estimate off by 15-fold (1.17 log units), on the low side, outside the stated range (above it).
By their numbers in this assay, from the lowest: compound 2; then compound 1; then compound 3.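

On a double-bonded ring carbon, the choice of amine matters: in this assay, pyrrolidin-1-yl in place of (3-methoxypropyl)amino gives a 13-fold higher number from compound 1 to compound 3 (1.10 log units; beyond the scatter) and so much weaker inhibition of growth. This single swap adds a ring, shortens the group and removes its hydrogen-bond donor, so it cannot show which of these differences counts. Nothing measured here accounts for the loss. Open-chain amines such as propylamino, or a ring amine such as morpholine, could help separate these differences. From the compounds shown here alone, whether this loss would recur on another core also remains open.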